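Swapping a dimethylaminophenyl for a chlorofluorophenyl

This account rests on a few compounds, and the source may have more. Where it says the series, first, only, none or still open, it means among the compounds named here.

Three compounds share one core and differ only in the group carried on the outer aromatic ring. Compound 1 `COC(=O)/C=C/c1cccc(N(Cc2ccc(/C=C/c3c(C)cc(C)cc3C)cc2)C(=O)C(C)C)c1` gives 149 nM in an assay on isolated protein with Bile acid receptor (Homo sapiens) as the target (on this read-out lower numbers stand for an effect already at smaller amounts and higher numbers for an effect only at larger amounts of compound), compound 2 `CCOc1cccc(-c2ccc(CN(C(=O)C(C)C)c3cccc(/C=C/C(=O)OC)c3)cc2)c1` gives 173 nM in this assay, and compound 3 `COC(=O)/C=C/c1cccc(N(Cc2ccc(-c3ccc(N(C)C)cc3)cc2)C(=O)C(C)C)c1` gives 57 nM in this assay. Compound 3 therefore stands lowest of the three, with a 2.6-fold lower number from compound 1 to compound 3 (0.42 log units; beyond the scatter) and a 3.0-fold lower number from compound 2 to compound 3 (0.48 log units; beyond the scatter), both beyond the scatter, while a 1.2-fold higher number from compound 1 to compound 2 (0.06 log units; within the scatter) stays within it.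

Compound 4 `COC(=O)/C=C/c1cccc(N(Cc2ccc(-c3ccc(F)c(Cl)c3)cc2)C(=O)C(C)C)c1` is the next step from compound 3: 3-chloro-4-fluorophenyl in place of 4-(dimethylamino)phenyl on an aromatic carbon. The steps that bear on this change are the two that lead into compound 3, because a 3.0-fold lower number from compound 2 to compound 3 (0.48 log units; beyond the scatter) and a 2.6-fold lower number from compound 1 to compound 3 (0.42 log units; beyond the scatter) both show that the 4-(dimethylamino)phenyl gives the lowest number among these groups. Giving it up for a group with no hydrogen-bond acceptor is expected to move the number in this assay back toward those of compounds 1 and 2, a modest rise rather than no change. The expected step is a 2.3-fold higher number from compound 3 to compound 4 (0.36 log units; beyond the scatter). Compound 4 is therefore estimated at 130 nM in this assay, within a range from 50 nM to 350 nM.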

Compound 4, half-maximal effective concentration: 129 nM
Compound 4: middle estimate off by 1.0-fold (0.00 log units), on the high side; low and high end bracket the measured number.
By their numbers in this assay, from the lowest: compound 3; then compounds 4, 1 and 2 (each within the scatter of the next).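

Replacing the 4-(dimethylamino)phenyl with 3-chloro-4-fluorophenyl in this assay gives a 2.3-fold higher number from compound 3 to compound 4 (0.35 log units; beyond the scatter) and shows that a third, quite different outer group also fails to match the low number of compound 3. Compound 4 cannot be separated from the two earlier compounds: the steps are a 1.3-fold lower number from compound 2 to compound 4 (0.13 log units; within the scatter) and a 1.2-fold lower number from compound 1 to compound 4 (0.06 log units; within the scatter) and neither exceeds the scatter, so among these four compounds only the 4-(dimethylamino)phenyl stands apart, while the three other groups, though very different in shape and atoms, give numbers that cannot be told apart. The data at hand offer no independent measurement that would account for this difference.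

As far as these compounds go, it remains open whether the lower number of compound 3 belongs to the dimethylamino group in particular or would also appear with another nitrogen group on this ring, such as a primary amine, a morpholine or a piperazine. A 4-methoxyphenyl would test whether an oxygen group in the same place can do the same, and no compound shown answers that question.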